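The compounds below may be only part of what the source reports. "The series", "measured", "known", "first", "only" and "open" are said of these compounds alone.

Compound 1 `CCC(CO)NCc1nc2c(OCC3CCCCC3)cccc2[nH]1` holds the lowest of the two numbers in an assay on cells for inhibition of interleukin-5 receptor subunit alpha (Mus musculus), read by WST assay, with a stated time of 48 h, in the presence of a further agent that is not named here (on this read-out higher numbers stand for weaker inhibition and lower numbers for stronger inhibition), where compound 1 gives 3500 nM. Its nearest neighbour is compound 2 `OCC(CC1CCCCC1)NCc1nc2c(OCC3CCCCC3)cccc2[nH]1`, which in this assay gives 5000 nM; the step of a 1.4-fold higher number from compound 1 to compound 2 (0.15 log units; within the scatter) leaves the two compounds indistinguishable. Compound 3 `c1ccc(NCc2nc3c(OCC4CCCCC4)cccc3[nH]2)cc1` has not yet been measured. It differs from compound 1 in that (phenyl in place of 1-(hydroxymethyl)propyl on an amine nitrogen). For the measured compounds named here, the only measured step, from compound 1 to compound 2, changed a group on the chain and kept the 1-(hydroxymethyl)propyl chain with its hydrogen-bond donor and acceptor in place; it bears only loosely on a change that removes that chain altogether and puts an aromatic ring on the amine nitrogen. Going by the values given here, no step here tests that removal. The step of a 1.4-fold higher number from compound 1 to compound 3 (0.15 log units; within the scatter) is therefore expected to be small, with wide uncertainty. Compound 3 is estimated to give 5000 nM, between 1200 nM and 20000 nM.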

Compound 3, half-maximal inhibitory concentration: > 30000 nM
Compound 3 ended at the assay's limit (the forecaster's own chance of this, stated with the estimate: 15%); middle value at least 6.0-fold (0.77 log units) away from the limit.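

On an amine nitrogen whose other neighbour is a saturated chain carbon, the group itself proved to matter in this assay: phenyl in place of 1-(hydroxymethyl)propyl gives an at least 8.5-fold higher number from compound 1 to compound 3 (0.93 log units; beyond the scatter), whereas the change further out on the chain gave only a 1.4-fold higher number from compound 1 to compound 2 (0.15 log units; within the scatter). The reading for compound 3 is a limit and not a number: the limit of > 30000 nM in this assay, at which 1 of the 3 values shown sits. Compound 1 and compound 2 both keep a hydroxyl-bearing chain on this nitrogen, and the phenyl of compound 3 brings an aromatic ring with no hydrogen-bond donor or acceptor.

As far as these compounds go, whether the step follows the loss of the hydroxyl or the arrival of the aromatic ring stays open, as the two change together here. A plain butyl chain or a benzyl group on the same amine nitrogen would separate the two.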